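Propargyl ether to propyl ether on a shared core

This account rests on a few compounds, and the source may have more. Where it says the series, first, only, none or still open, it means among the compounds named here.

Measured so far:
compound 1 `C#CCO[C@@H]1C=CC(=O)[C@@H](CO)O1` — 10400 nM
compound 2 `O=C1C=C[C@@H](OCc2ccccc2)O[C@@H]1CO` — 11100 nM

Among the compounds with values here, in a functional assay on MCF7 cells (Homo sapiens) for inhibition, read by MTT assay, with a stated time of 72 h (a higher number here means a weaker inhibitor, a lower number a stronger inhibitor), compound 1 gives 10400 nM; of the two numbers known so far, this is the lower one. Compound 2 gives 11100 nM in this assay, and the two values lie within the usual scatter of each other, so neither compound can be called the stronger inhibitor. Both share the same core and differ only in the group carried on the oxygen.

Compound 3 `CCCO[C@@H]1C=CC(=O)[C@@H](CO)O1` has not yet been measured. It differs from compound 1 in one place: ethyl in place of ethynyl on a saturated chain carbon bound to an oxygen on a saturated carbon The propargyloxy group thus becomes a propoxy group, with the rest of the molecule unchanged.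

Within the data shown here, no measured pair shows the effect of this particular change. Among the measured compounds shown here, the only guidance is that compound 1 and compound 2 carry quite different groups at that position yet give numbers within the scatter, which suggests the position tolerates variation. In this assay the expected step is a 1.2-fold higher number from compound 1 to compound 3 (0.06 log units; within the scatter), small and without a clear direction. Compound 3 is expected to give about 12000 nM in this assay, within a range from 5000 nM to 30000 nM.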

Compound 3, half-maximal inhibitory concentration: 18300 nM
Compound 3: middle estimate off by 1.5-fold (0.18 log units), on the low side; measured number inside the range.
By their numbers in this assay, from the lowest: compounds 1, 2 and 3 (each within the scatter of the next).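

Within the data shown here, this is the first comparison in which a single change at this position can be read on its own. In this assay, the change from propargyl to propyl, with ethyl in place of ethynyl on a saturated chain carbon bound to an oxygen on a saturated carbon, gives a 1.8-fold higher number from compound 1 to compound 3 (0.25 log units; within the scatter) and so stays inside the usual variation between repeated measurements. The triple bond outside aromatic rings can therefore be removed from this chain with no difference that can be told apart from that variation, though a single pair cannot show that the same would hold on another core or in another cell line. Nothing measured here bears on the reason for this result.

The compounds shown leave open how far this tolerance extends, since a longer chain such as hexyl on the same oxygen, or a chain ending in an amine or a carboxylic acid, might or might not give numbers in the same range. They also cannot show whether any group at this position would give a step that lies clearly beyond the scatter.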